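Vero cell cytotoxicity in a small amide series

The source may hold more compounds than are shown below. What is called first, only, known or untested is meant among the compounds shown, and "the series" means these compounds.

Measured compounds in an ADME assay on Vero cells (Chlorocebus sabaeus) for cytotoxicity, read by MTT assay, with a stated time of 72 h; on this read-out lower numbers stand for higher toxicity in this test and higher numbers for lower toxicity in this test:
- Compound 1, `COC(=O)c1cc(-c2cccc(NC(=O)c3ccc(/C=C/C(=O)c4cccnc4)cc3)c2)on1`, gives "not determined" (no result reported).
- Compound 2, `COC(=O)c1cc(-c2cccc(NC(=O)c3ccc(/C=C/C(=O)c4cccc(OC)c4)cc3)c2)on1`, gives > 100 ug/mL.
- Compound 3, `COC(=O)c1cc(-c2cccc(NC(=O)c3ccc(C4OC4C(=O)c4ccc(Cl)cc4)cc3)c2)on1`, gives > 20 ug/mL.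

Compound 1 has no result in this assay, its entry being "not determined" (no result reported). Compound 2 gives > 100 ug/mL in this assay, which is a limit of the assay and not a number. Compound 3 gives > 20 ug/mL in this assay, also a limit and not a number. Compound 3 therefore stands at a limit, with one further limit and one entry without a number beside it. Among the measured compounds shown here, the only one-place step among the measured compounds, a step that the two limits leave unreadable from compound 2 to compound 3, is left unreadable by the two limits (the limit of > 100 ug/mL in this assay, at which 1 of the 3 values shown sits, and (the limit of > 20 ug/mL in this assay, at which 1 of the 3 values shown sits)).

Compound 4, `COC(=O)c1cc(-c2cccc(NC(=O)c3ccc(/C=C/C(=O)c4ccc(F)cc4F)cc3)c2)on1`, differs from compound 3 by 2-((2,4-difluorophenyl)carbonyl)ethenyl in place of 3-((4-chlorophenyl)carbonyl)oxiran-2-yl on an aromatic carbon. For the measured compounds named here, no measured step reads on this change; the step from compound 2 to compound 3 touched the same oxiranyl group but its size is hidden. Compound 4 is therefore expected to sit near the limits seen so far, with an expected step that the limit leaves unreadable from compound 3 to compound 4 that cannot be called a change beyond the scatter. Compound 4 is estimated at 100 ug/mL, in the range 40 ug/mL to 250 ug/mL, most likely reported again only as a limit.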

Compound 4, half-maximal cytotoxic concentration: > 40 ug/mL
Compound 4: a limit, no number; the forecaster's own chance of this, stated with the estimate: 70%; the middle value does not contradict the limit.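

Compound 2, compound 3 and compound 4 all give limits, not numbers, in this assay, so the steps from compound 3 to compound 4 and from compound 2 to compound 4 cannot be read. The compounds shown leave open whether any of these changes shifts the half-maximal cytotoxic concentration at all.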